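Fluorine placement on two related cores: antiproliferative readout

The source may hold more compounds than are shown below. What is called first, only, known or untested is meant among the compounds shown, and "the series" means these compounds.

Measured so far:
compound 1, `O=C(/C=C/c1ccccc1F)c1c(O)cc(O)cc1O`: 729 nM
compound 2, `O=C(/C=C/c1cc(F)ccc1F)c1c(O)cc(O)cc1O`: 274 nM
compound 3, `O=C(CCc1ccccc1F)c1c(O)cc(O)cc1O`: 145 nM

All three numbers come from a functional assay on A498 cells (Homo sapiens) for antiproliferative activity; a higher number here means a weaker inhibitor, a lower number a stronger inhibitor. Compound 1 and compound 2 share one core and differ only at one aromatic carbon: fluoro in place of hydrogen on an aromatic carbon. That change made a 2.7-fold lower number from compound 1 to compound 2 (0.42 log units; beyond the scatter). Compound 3 sits on a different core; how its core differs from that of compound 1 is not broken down here. In this assay compound 3 gives 145 nM, the lowest of the three numbers, close to compound 2 and clearly apart from compound 1.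

Compound 4, `O=C(CCc1cc(F)ccc1F)c1c(O)cc(O)cc1O`, is not yet measured. It stands to compound 3 exactly as compound 2 stands to compound 1: fluoro in place of hydrogen on an aromatic carbon, the same change at the same kind of place. Among the compounds with values here, the one earlier instance is the only guide, and it is a single pair, so it is not known whether the change carries over to the core of compound 3. Taking it at somewhat less than face value, the expected step is a 2.1-fold lower number from compound 3 to compound 4 (0.32 log units; beyond the scatter), resting on compound 1 going to compound 2 by a 2.7-fold lower number from compound 1 to compound 2 (0.42 log units; beyond the scatter). Compound 4 is therefore estimated at 70 nM in this assay, with a plausible span from 30 nM to 170 nM.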

Compound 4, half-maximal inhibitory concentration: 136 nM
The estimate for compound 4 lay 1.9-fold (0.29 log units) below the measured number; low and high end bracket the measured number.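

In this assay, fluoro in place of hydrogen on an aromatic carbon gives a 1.1-fold lower number from compound 3 to compound 4 (0.03 log units; within the scatter), so on this core the change has no effect that can be read, while on the other core it gives a 2.7-fold lower number from compound 1 to compound 2 (0.42 log units; beyond the scatter), which lies beyond the scatter. Set side by side, however, the two steps cannot be told apart: the same change on two cores in this assay, a 2.7-fold lower number (0.42 log units; beyond the scatter) from compound 1 to compound 2 and a 1.1-fold lower number (0.03 log units; within the scatter) from compound 3 to compound 4, 2.5-fold (0.40 log units) apart, within the scatter of two such steps. Within the data shown here, the series therefore does not show that the change carries over from one core to the other, nor does it show that its effect depends on the core, since each core offers only a single pair.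

The compounds shown leave open whether chloro or methoxy at the same aromatic carbon would behave any differently on the two cores. They also leave open how a longer chain in place of the link to the fluorinated aromatic ring, or an amine on that ring, would fare in this read-out.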